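The source may hold more compounds than are shown below. What is called first, only, known or untested is meant among the compounds shown, and "the series" means these compounds.

Measured compounds in an assay on CHO cells for displacement of a labelled ligand from adenosine receptor A1 (Homo sapiens), read by scintillation counting, tested at 10 uM; a higher number here means more inhibition at the concentration tested (going by the name of the read-out), a lower number less inhibition:
compound 1 `CC(C)(C)Cc1c(-c2cccc(F)c2F)sc(N)c1C(=O)c1ccc(Cl)cc1` gives 1%
compound 2 `CC(C)(C)Cc1c(-c2ccc(F)cc2F)sc(N)c1C(=O)c1ccc(Cl)cc1` gives 1%
compound 3 `CC(C)(C)Cc1c(-c2cc(F)ccc2F)sc(N)c1C(=O)c1ccc(Cl)cc1` gives 3%

All three compounds share one core and differ only in the placement of two fluorines on the pendant difluorophenyl ring. Each gives a low inhibition in this assay. Compound 3 has the highest number of the three, but its nearest neighbour compound 1 sits a number 2 percentage points higher from compound 1 to compound 3 (within the scatter) and its furthest neighbour compound 2 sits a number 2 percentage points higher from compound 2 to compound 3 (within the scatter); both steps lie within the scatter, so the number for compound 3 is level with those of compound 1 and compound 2.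

Compound 4 `CC(C)(C)Cc1c(-c2c(F)cccc2F)sc(N)c1C(=O)c1ccc(Cl)cc1` is not yet measured. It differs from compound 3 by 2,6-difluorophenyl in place of 2,5-difluorophenyl on an aromatic carbon. Within the data shown here, the steps that bear on this change are no change at the digits printed from compound 1 to compound 2 (within the scatter), a number 2 percentage points higher from compound 1 to compound 3 (within the scatter) and a number 2 percentage points higher from compound 2 to compound 3 (within the scatter): moving the second fluorine around the ring has so far produced nothing beyond the scatter. The same is therefore expected here, no step beyond the scatter, with the change estimated at a number 1 percentage points lower from compound 3 to compound 4 (within the scatter). Compound 4 is accordingly expected to give about 2% in this assay, with a range from -6% to 10%.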

Compound 4, a percentage reported as inhibition, at one concentration (the size of the read-out at that concentration, not a potency): 1%
Beside the measured number, compound 4's estimate is 1 percentage points above it; measured number inside the range.
By their numbers in this assay, from the lowest: compounds 1, 2, 4 and 3 (each within the scatter of the next).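

In this assay the 2,6-difluorophenyl group at this place, on the aromatic carbon next to the ring sulfur, gives a number 2 percentage points lower from compound 3 to compound 4 (within the scatter) and no change at the digits printed from compound 2 to compound 4 (within the scatter) and also no change at the digits printed from compound 1 to compound 4 (within the scatter). With this fourth arrangement of the two fluorines, all the difluorophenyl isomers shown are level at this position, so the change to 2,6-difluorophenyl separates it from none of the other three. Nothing at hand bears on why the readings stay this low.

Still open, going by these compounds, is whether a substituent other than fluorine on this ring, such as an aminomethyl group or a carboxylic acid, would move the number beyond the scatter. Equally open, on these data alone, is whether a longer chain in place of the neopentyl group would lift the shared core from this low level.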